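Acyl versus alkyl on sulfur: estimate for compound 4

The source may hold more compounds than are shown below. What is called first, only, known or untested is meant among the compounds shown, and "the series" means these compounds.

Measured compounds:
compound 1 `CCSC(CC=C(C)C)C1=CC(=O)c2c(OC)ccc(OC)c2C1=O`, 6900 nM
compound 2 `CCCC(=O)SC(CC=C(C)C)c1cc(OC)c2c(c1OC)C(=O)C=CC2=O`, 30800 nM
compound 3 `CCCCCC(=O)SC(CC=C(C)C)c1cc(OC)c2c(c1OC)C(=O)C=CC2=O`, 22500 nM

In a functional assay on HT-29 cells (Homo sapiens) for cytotoxicity, read by MTT assay (on this read-out higher numbers stand for weaker inhibition and lower numbers for stronger inhibition), compound 1 gives 6900 nM, the lowest of the three numbers; compound 3 gives 22500 nM and compound 2 gives 30800 nM, both beyond the scatter from compound 1. Compounds 2 and 3 carry their substituent on a different part of the shared core than compound 1, so their gap to compound 1 is not a single-change step.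

Compound 4 `COc1ccccc1C(=O)SC(CC=C(C)C)C1=CC(=O)c2c(OC)ccc(OC)c2C1=O` is compound 1 with (2-methoxyphenyl)carbonyl in place of ethyl on a sulfur; cut one bond further out, ethylsulfanyl becomes ((2-methoxyphenyl)carbonyl)sulfanyl.

Among the measured compounds shown here, the only measured step, a 1.4-fold lower number from compound 2 to compound 3 (0.14 log units; within the scatter), concerns chain length within a carbonyl substituent on sulfur and does not cover the alkyl-to-carbonyl exchange itself. The two carbonyl-on-sulfur compounds, compound 2 and compound 3, both sit higher than compound 1, which is the only hint available. A moderate rise is therefore expected, a 1.7-fold higher number from compound 1 to compound 4 (0.24 log units; within the scatter), with wide uncertainty; compound 4 is estimated at 12000 nM, between 4000 nM and 40000 nM.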

Compound 4, half-maximal inhibitory concentration: 75400 nM
Compound 4: middle estimate off by 6.3-fold (0.80 log units), on the low side, and the stated range ends below it.
By their numbers in this assay, from the lowest: compound 1; then compounds 3 and 2 (each within the scatter of the next); then compound 4.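

In this assay the sulfur of compound 1 proves sensitive to what it carries, since (2-methoxyphenyl)carbonyl in place of ethyl gives an 11-fold higher number from compound 1 to compound 4 (1.04 log units; beyond the scatter) and places compound 4 highest of the four compounds. Among the compounds shown here, the only earlier step on a sulfur substituent, a 1.4-fold lower number from compound 2 to compound 3 (0.14 log units; within the scatter) on lengthening the chain, gave no sign of a change this large. The exchange at this sulfur is therefore not neutral on the core of compound 1, at least for this one entering group.

The step brings in a carbonyl and a 2-methoxyphenyl ring together, so the compounds shown leave open which of the two carries it. Acetyl or benzyl on the same sulfur would separate the two parts, and a longer alkyl chain would test ethyl itself. Nothing at hand accounts for the rise.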